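The source may report more compounds than this note shows. Statements on the series, on what has been measured and on what is new or still open speak of the compounds shown alone.

In a functional assay on KYSE-410 cells (Homo sapiens) for antiproliferative activity, read by MTT assay, with a stated time of 72 h; a lower number here means a stronger inhibitor, a higher number a weaker inhibitor:
- Compound 1 `O=C(Nc1cccc(F)c1)c1cc(=O)[nH]c2cc(F)ccc12`: > 20000 nM
- Compound 2 `Cc1cc(-c2ccc3c(C(=O)Nc4cccc(F)c4)cc(=O)[nH]c3c2)c(C)cc1F`: > 20000 nM
- Compound 3 `O=C(Nc1cccc(F)c1)c1cc(=O)[nH]c2cc(-c3ccc(F)c(CO)c3)ccc12`: > 20000 nM

All three values are limits of the assay, not numbers, and the limit of > 20000 nM in this assay, at which 3 of the 3 values shown sit, sums up the set. Compound 3 stands at the limit of > 20000 nM.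

Compound 4 `C=Cc1ccc2c(C(=O)Nc3cccc(F)c3)cc(=O)[nH]c2c1` carries vinyl in place of 4-fluoro-3-(hydroxymethyl)phenyl on an aromatic carbon. The measured steps change the group on that same aromatic carbon: a step that the two limits leave unreadable from compound 1 to compound 2, a step that the two limits leave unreadable from compound 1 to compound 3 and a step that the two limits leave unreadable from compound 2 to compound 3. None of them has a readable size, so no step beyond the scatter is expected in this assay. The expected change is a number no higher from compound 3 to compound 4 (the limit leaves the size open). Compound 4 is estimated at 20000 nM, with an expected range from 8000 nM to 40000 nM.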

Compound 4, half-maximal inhibitory concentration: 13600 nM
Compound 4: middle estimate off by 1.5-fold (0.17 log units), on the high side, and the stated range covers the measured number.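

In this assay, among these compounds, compound 4 gives 13600 nM, the first value at this aromatic carbon that is a number and not a limit. The other values remain limits of the assay: the limit of > 20000 nM in this assay, at which 3 of the 4 values shown sit. Measured against those limits, the change to vinyl gives an at least 1.4-fold lower number from compound 3 to compound 4 (0.16 log units; that floor lies within the scatter), an at least 1.4-fold lower number from compound 2 to compound 4 (0.16 log units; that floor lies within the scatter) and an at least 1.4-fold lower number from compound 1 to compound 4 (0.16 log units; that floor lies within the scatter), so each step is only a floor and its true size cannot be read.

Going by these compounds, it remains open whether an ethyl group, an amine or a carboxylic acid on this carbon would give a number in this assay, and how any of them would compare with vinyl.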